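The compounds below may be only part of what the source reports. "The series", "measured", "known", "first", "only" and "open" are said of these compounds alone.

Measured compounds:
Compound 1 `Cc1ncc(-c2ccccc2NCC2=NCCN2)o1`: in a functional assay for activation of Alpha-1B adrenergic receptor (Homo sapiens), read by calcium flux (on this read-out lower numbers stand for an effect already at smaller amounts and higher numbers for an effect only at larger amounts of compound), compound 1 gives < 5020 nM, a limit of the assay and not a number.
Compound 2 `c1ccc(-c2ccccc2NCC2=NCCN2)nc1`: in this assay compound 2 gives 30.2 nM.

Compound 2 holds the only number shown in this assay; the one further value is a limit, and the limit of < 5020 nM in this assay, at which 1 of the 2 values shown sits, records that one of the two values sits there. The step from compound 1 to compound 2, a step that the limit leaves unreadable from compound 1 to compound 2, is accordingly of unreadable size.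

Compound 3 `CO/N=C(\C)c1ccccc1NCC1=NCCN1` differs from compound 2 in one place: a group of 5 heavy atoms (3 carbon, 1 nitrogen, 1 oxygen; no ring) in place of a group of 6 heavy atoms (5 carbon, 1 nitrogen; one six-membered aromatic ring with 1 hetero atom), on an aromatic carbon. Going by the values given here, no measured step bears on this exchange; the single step is the unreadable one above and concerns a different pair of groups. The data thus fix neither size nor direction. The expected step from compound 2 to compound 3 is a 5.0-fold higher number from compound 2 to compound 3 (0.70 log units; beyond the scatter) in this assay, set wide for want of a comparable step. Compound 3 is estimated at 150 nM, in the range 20 nM to 1500 nM.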

Compound 3, half-maximal effective concentration: < 5020 nM
Compound 3 was reported as a limit; the forecaster's own chance of this, stated with the estimate: 15%; the middle value lies beyond the limit too.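

In this assay compound 3 gives < 5020 nM, a limit of the assay and not a number, so the steps to compound 3 from compound 1 and compound 2 cannot be read. The compounds shown leave open how compound 1 and compound 3 compare with compound 2 in size of effect.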